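Replacing furan-2-yl with 2-fluoropyridin-4-yl: expected cytotoxicity

This account rests on a few compounds, and the source may have more. Where it says the series, first, only, none or still open, it means among the compounds named here.

Compound 1 `Cc1cnc(Nc2ccc(C#N)cc2)nc1Nc1c(F)cc(-c2ccco2)cc1F` and compound 2 `Cc1cnc(Nc2ccc(C#N)cc2)nc1Nc1c(F)cc(-c2cccs2)cc1F` share a core and differ only in the five-membered ring attached to it. In a toxicity assay on MT4 cells (Homo sapiens) for cytotoxicity, read by MTT assay, with a stated time of 5 days (a lower number here means that less compound is tolerated, a higher number that more compound is tolerated), compound 1 gives 8100 nM, and compound 2 gives 8000 nM; the step is a 1.0-fold lower number from compound 1 to compound 2 (0.01 log units; within the scatter). Compound 3 `Cc1cc(-c2ccco2)cc(C)c1Nc1ccnc(Nc2ccc(C#N)cc2)n1` is built on a different core carrying two methyl groups, with the same furan-2-yl group as compound 1. In this assay compound 3 gives 1700 nM, the lowest of the three numbers, with the gaps to compound 2 and to compound 1 both lying beyond the scatter.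

Compound 4 `Cc1cc(-c2ccnc(F)c2)cc(C)c1Nc1ccnc(Nc2ccc(C#N)cc2)n1` arises from compound 3 by one change: 2-fluoropyridin-4-yl in place of furan-2-yl on an aromatic carbon. Going by the values given here, none of the measured steps exchanges a five-membered ring for a six-membered one; the only step recorded, from compound 1 to compound 2, swaps one five-membered ring for another and stays within the scatter, so it bears on the present change only loosely. Among the compounds with values here, with no step pointing clearly in either direction, one expects compound 4 to move little from compound 3, if anything towards a somewhat higher number. Compound 4 is estimated at 2500 nM, within 900 nM to 7000 nM, an expected step of a 1.5-fold higher number from compound 3 to compound 4 (0.17 log units; within the scatter).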

Compound 4, half-maximal cytotoxic concentration: 6000 nM
For compound 4 the middle estimate is 2.4-fold (0.38 log units) below the measured one, and the stated range covers the measured number.
By their numbers in this assay, from the lowest: compound 3; then compounds 4, 2 and 1 (each within the scatter of the next).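

In this assay, 2-fluoropyridin-4-yl in place of furan-2-yl on this aromatic carbon, meta to two methyl groups, gives a 3.5-fold higher number from compound 3 to compound 4 (0.55 log units; beyond the scatter), so this place responds to the exchange with more compound tolerated. Going by these compounds alone, the only earlier step, a 1.0-fold lower number from compound 1 to compound 2 (0.01 log units; within the scatter), exchanged one five-membered aromatic ring for another on a different core and stayed within the scatter, whereas this step brings in a six-membered aromatic ring and goes beyond it. Nothing on hand accounts for the shift, and these two compounds cannot separate the ring size, the ring nitrogen and the fluorine from one another.

Going by these compounds, it remains open whether the same exchange would move the number in the same direction on the core of compound 1, where the furan-2-yl group also occurs. Also open, on these data alone, is where a pyridinyl group without the fluorine, or an amine or a carboxylic acid on this aromatic carbon, would fall in this assay relative to compound 3 and compound 4.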